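The source may report more compounds than this note shows. Statements on the series, on what has been measured and on what is new or still open speak of the compounds shown alone.

Compound 1 `NC1CCC(Nc2nc(NCc3ccc(-n4cccn4)cc3)c3ncn(C4CCCC4)c3n2)CC1`: in a functional assay on K562 cells (Homo sapiens) for inhibition, with a stated time of 72 h (a lower number here means a stronger inhibitor, a higher number a weaker inhibitor), compound 1 gives 119 nM.
Compound 2 `NC1CCC(Nc2nc(NCc3ccc(-c4cccs4)nc3)c3ncn(C4CCCC4)c3n2)CC1`: in this assay compound 2 gives 100 nM.

Among the measured compounds shown here, compound 2 holds the lowest of the two numbers measured so far, but compound 1, its nearest neighbour, lies within the scatter of it, so no order between the two can be claimed. For the measured compounds named here, the one measured step, a 1.2-fold lower number from compound 1 to compound 2 (0.08 log units; within the scatter), swapped one two-ring aryl group for another at the same place and moved nothing beyond the scatter.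

Compound 3 `NC1CCC(Nc2nc(NCc3cc(Cl)ccc3O)c3ncn(C4CCCC4)c3n2)CC1` is not yet measured. It differs from compound 2 as follows: 5-chloro-2-hydroxyphenyl in place of 6-(thiophen-2-yl)pyridin-3-yl on a saturated chain carbon bound to a nitrogen on an aromatic ring. Going by the values given here, the only step that bears on this change is a 1.2-fold lower number from compound 1 to compound 2 (0.08 log units; within the scatter), which was within the scatter; however, both measured groups carry two aromatic rings, whereas the entering group carries one, so that step gives limited guidance. A modest move toward a higher number, or none beyond the scatter, is expected, a 1.8-fold higher number from compound 2 to compound 3 (0.26 log units; within the scatter). Compound 3 is therefore estimated at 180 nM, with a range from 60 nM to 550 nM.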

Compound 3, half-maximal inhibitory concentration: 690 nM
Compound 3: the middle estimate sits 3.8-fold (0.58 log units) below what was measured; measured number outside the range, above it.
By their numbers in this assay, from the lowest: compounds 2 and 1 (each within the scatter of the next); then compound 3.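

The group on the saturated chain carbon bound to a nitrogen on an aromatic ring is not interchangeable in this assay: 5-chloro-2-hydroxyphenyl gives a 6.9-fold higher number from compound 2 to compound 3 (0.84 log units; beyond the scatter), and a 5.8-fold higher number from compound 1 to compound 3 (0.76 log units; beyond the scatter). The two groups with two aromatic rings remain within the scatter of each other, while the entering group with one aromatic ring stands apart from both, although this change also alters the heavy-atom count, the hetero atoms and the hydrogen-bond donors at once. Nothing available explains the shift.

Whether the loss of the second aromatic ring, the hydroxy group or the chlorine accounts for the step remains open. A plain phenyl group, or a methoxy group in place of the hydroxy, at this place would bear on that question.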